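A few compounds are considered here, and "the series" means these few. Any claim that something is new, unique, unknown or untested is made for them only; others in the source may bear on it.

Of the compounds shown here, three from this series have been tested in a physicochemical assay for solubility, read by HPLC, in simulated intestinal fluid, with a stated time of 16 h, at pH 6.5, tested at 2.5 mg/mL; on this read-out lower numbers stand for lower solubility and higher numbers for higher solubility. Compound 1, `CC[C@@]1(c2ccccc2)COc2c(C(=O)NC)cc(C(=O)N[C@H]3[C@@H]4COC[C@@H]43)cc21`, gives 93 ug/mL in this assay. Compound 2, `CNC(=O)c1cc(C(=O)NC2CC2)cc2c1OC[C@@]2(C)c1ccccc1`, gives 585 ug/mL in this assay, which is the higher of the two numbers, with compound 1 standing a good deal lower, beyond the usual scatter. Compound 3, `CNC(=O)c1cc(C(=O)N[C@H]2C[C@@H]2C)cc2c1OC[C@@]2(CO)c1ccccc1`, gives > 1000 ug/mL in this assay, and this is a limit of the assay rather than a number.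

The step under consideration leads from compound 2 to compound 4, `CNC(=O)c1cc(C(=O)N[C@H]2C[C@@H]2C)cc2c1OC[C@@]2(C)c1ccccc1`, which has not yet been measured in this assay. The difference between the two structures is methyl in place of hydrogen on a saturated ring carbon. Going by the values given here, no measured pair of compounds differing in the same way is available, so the size of the step can only be guessed from compound 2 itself. A change of this kind is expected to leave the solubility of compound 4 close to that of compound 2, with a step from compound 2 to compound 4 of a 1.4-fold lower number from compound 2 to compound 4 (0.14 log units; within the scatter) expected, downward if anything and most likely within the scatter. Compound 4 is therefore estimated to give 420 ug/mL in this assay, in a range from 150 ug/mL to 1000 ug/mL.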

Compound 4, solubility: 88 ug/mL
Beside the measured number, compound 4's estimate is 4.8-fold (0.68 log units) above it; the whole stated range lies above it.
By their numbers in this assay, from the lowest: compounds 4 and 1 (each within the scatter of the next); then compound 2. At a limit, above all of these: compound 3.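

In this assay, the change from cyclopropylcarbamoyl to (2-methylcyclopropyl)carbamoyl gives a 6.6-fold lower number from compound 2 to compound 4 (0.82 log units; beyond the scatter), so a single added methyl on this three-membered ring, next to the ring atom that bears a large group, is enough to move the read-out beyond the scatter. With the 2-methylcyclopropyl group held in place, hydrogen in place of hydroxy on a saturated chain carbon bound to a saturated ring carbon gives an at least 11-fold lower number from compound 3 to compound 4 (1.05 log units; beyond the scatter), which shows a second place on the molecule where one change carries a step beyond the scatter. That second step starts from a limit of the assay and not from a number: the limit of > 1000 ug/mL in this assay, at which 1 of the 4 values shown sits.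

Going by these compounds, each change is read only once here, so whether either step would repeat on another member of the series stays open. Also open, on these data alone, is how an ethyl, a methoxy or an amine in place of the methyl on the cyclopropyl ring would read.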